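Swapping the pendant aryl group on a shared core

The source may report more compounds than this note shows. Statements on the series, on what has been measured and on what is new or still open speak of the compounds shown alone.

Of the compounds shown here, two have been measured in a functional assay on MKN-45 cells (Homo sapiens) for cytotoxicity, read by MTT assay, with a stated time of 72 h; on this read-out higher numbers stand for weaker inhibition and lower numbers for stronger inhibition. Compound 1, `COc1ccc(-c2ccnc(C(=O)Nc3ccc(Oc4ccnc5cc(OCCCN6CCCCC6)c(OC)cc45)c(F)c3)c2)cc1`, gives 570 nM in this assay. Compound 2, `COc1cc2c(Oc3ccc(NC(=O)c4cc(-c5ccccc5F)ccn4)cc3F)ccnc2cc1OCCCN1CCN(C)CC1`, gives 150 nM in this assay, the lower of the two numbers; the gap to compound 1 lies beyond the usual scatter. Compound 1 and compound 2 differ in two places at once, in the pendant aryl group and in the amine at the end of the chain, so the two numbers do not separate those contributions.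

Compound 3, `COc1ccc(-c2ccnc(C(=O)Nc3ccc(Oc4ccnc5cc(OCCCN6CCN(C)CC6)c(OC)cc45)c(F)c3)c2)cc1`, keeps the chain and amine of compound 2 and changes only the aryl group: 4-methoxyphenyl in place of 2-fluorophenyl on an aromatic carbon. Among the compounds with values here, no single-change step within the measured pair isolates this change. The step from compound 2 to compound 3 is therefore expected to be modest and most likely toward a higher number, as a 2.2-fold higher number from compound 2 to compound 3 (0.34 log units; beyond the scatter), since compound 3 carries the aryl group of compound 1, which gave 570 nM. Compound 3 is estimated at 330 nM in this assay, with a range from 120 nM to 950 nM.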

Compound 3, half-maximal inhibitory concentration: 250 nM
Beside the measured number, compound 3's estimate is 1.3-fold (0.12 log units) above it, and the stated range covers the measured number.
By their numbers in this assay, from the lowest: compounds 2 and 3 (each within the scatter of the next); then compound 1.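

In this assay the aryl position, on an aromatic carbon opposite the ring nitrogen, can now be read on its own: with 4-methoxyphenyl in place of 2-fluorophenyl and the 4-methylpiperazin-1-yl end held constant, the change gives a 1.7-fold higher number from compound 2 to compound 3 (0.22 log units; within the scatter) and so does not separate the two aryl groups. Within the data shown here, the amine at the end of the chain can also be read on its own for the first time: with the 4-methoxyphenyl group held constant, 4-methylpiperazin-1-yl in place of piperidin-1-yl gives a 2.3-fold lower number from compound 1 to compound 3 (0.36 log units; beyond the scatter) and is the only single change here that lies beyond the scatter. No measurement at hand accounts for either step.

From the compounds shown here alone, the aryl step rests on the 4-methylpiperazin-1-yl pair alone and the amine step on the 4-methoxyphenyl pair alone, so whether either step carries over to the other partner group remains open. Also open, going by these compounds, is how a morpholine at the end of the chain, or an unsubstituted phenyl at the aryl position, would read in this assay alongside these compounds.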